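Swapping an epoxide ketone for a chalcone on Vero cells

The source may hold more compounds than are shown below. What is called first, only, known or untested is meant among the compounds shown, and "the series" means these compounds.

Compound 1 `COC(=O)c1cc(-c2cccc(NC(=O)c3ccc(C4OC4C(=O)c4ccc(Cl)cc4)cc3)c2)on1` is one of three related amides tested in an ADME assay on Vero cells (Chlorocebus sabaeus) for cytotoxicity, read by MTT assay, with a stated time of 72 h; a lower number here means that less compound is tolerated, a higher number that more compound is tolerated. In this assay compound 1 gives only a limit, > 20 ug/mL, so its true value is not a number. Compound 3 `COC(=O)c1cc(-c2cccc(NC(=O)c3ccc(/C=C/C(=O)c4cc(F)ccc4F)cc3)c2)on1` likewise gives only a limit in this assay, > 40 ug/mL. Compound 2 `COC(=O)c1cc(-c2cccc(NC(=O)c3ccc(/C=C/C(=O)c4cccs4)cc3)c2)on1` has no result in this assay, "not determined" (no result reported). The one single-point step among these, a step that the two limits leave unreadable from compound 1 to compound 3, connects two limits and therefore has no readable size; what the two measured results offer, the limit of > 20 ug/mL in this assay, at which 1 of the 3 values shown sits, and (the limit of > 40 ug/mL in this assay, at which 1 of the 3 values shown sits), are themselves only limits.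

Compound 4 `COC(=O)c1cc(-c2cccc(NC(=O)c3ccc(/C=C/C(=O)c4cccc(Br)c4)cc3)c2)on1` differs from compound 1 by 2-((3-bromophenyl)carbonyl)ethenyl in place of 3-((4-chlorophenyl)carbonyl)oxiran-2-yl on an aromatic carbon. This resembles the change from compound 1 to compound 3 in replacing the oxiranyl ketone with an ethenyl ketone, yet that step gives no size, so no direction beyond the scatter can be expected for a step that the limit leaves unreadable from compound 1 to compound 4. Compound 4 is therefore estimated near the tested limits, at 30 ug/mL, within 15 ug/mL to 60 ug/mL, and most likely again reported only as a limit.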

Compound 4, half-maximal cytotoxic concentration: > 100 ug/mL
Compound 4 gave a limit, no number (the forecaster's own chance of this, stated with the estimate: 65%); at least 3.3-fold (0.52 log units) between middle value and limit.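

In this assay compound 4 gives only a limit, > 100 ug/mL. Its steps from compound 1 and from compound 3 cannot be read, as all three results are limits. The compounds shown leave open the concentration at which any of them harms the cells, and whether these group changes alter it.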